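Swapping furan-2-yl for 4-methoxyphenyl on a shared core

The compounds below may be only part of what the source reports. "The series", "measured", "known", "first", "only" and "open" are said of these compounds alone.

Compound 1 (`Cn1c(=O)c(=O)n(C2CCCC2)c2nc(N/N=C/c3ccc(O)cc3)ncc21`) gives 72500 nM
Compound 2 (`Cn1c(=O)c(=O)n(C2CCCC2)c2nc(N/N=C/c3ccc(Cl)cc3)ncc21`) gives 9810 nM
Compound 3 (`Cn1c(=O)c(=O)n(C2CCCC2)c2nc(N/N=C/c3ccco3)ncc21`) gives 78700 nM

These numbers come from a functional assay on HCT-116 cells (Homo sapiens) for antiproliferative activity, read by MTT assay (a lower number here means a stronger inhibitor, a higher number a weaker inhibitor), and cover three compounds that differ in one group only. Compound 3 (78700 nM) sits at the weak end of this small range, a place it shares with compound 1: a 1.1-fold higher number from compound 1 to compound 3 (0.04 log units; within the scatter) stays small, while an 8.0-fold higher number from compound 2 to compound 3 (0.90 log units; beyond the scatter) does not.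

Compound 4 (`COc1ccc(/C=N/Nc2ncc3c(n2)n(C2CCCC2)c(=O)c(=O)n3C)cc1`) is still unmeasured. It carries 4-methoxyphenyl in place of furan-2-yl on a carbon with a double bond to nitrogen. Those same two steps bear on this change, since each swaps furan-2-yl with another phenyl group at that place. The gap between the two phenyl groups is also relevant (a 7.4-fold lower number from compound 1 to compound 2 (0.87 log units; beyond the scatter)). Among the measured compounds shown here, no methoxy example has been measured, so a step between the two earlier sizes is the fair expectation, towards a lower number. a 3.1-fold lower number from compound 3 to compound 4 (0.50 log units; beyond the scatter) is the expected outcome in this assay for this change. Compound 4 is estimated at about 25000 nM (range 8000 nM to 75000 nM).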

Compound 4, half-maximal inhibitory concentration: 36100 nM
Estimate against measurement, compound 4: 1.4-fold (0.16 log units) below; low and high end bracket the measured number.
By their numbers in this assay, from the lowest: compound 2; then compounds 4, 1 and 3 (each within the scatter of the next, the first and the last beyond it).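

In this assay the change from furan-2-yl to 4-methoxyphenyl gives a 2.2-fold lower number from compound 3 to compound 4 (0.34 log units; beyond the scatter) and so, unlike the hydroxy group of compound 1, an oxygen-bearing group on the phenyl ring now stands apart from furan-2-yl. Yet methyl on that oxygen gives a 2.0-fold lower number from compound 1 to compound 4 (0.30 log units; within the scatter) and so cannot be read as a real change from hydroxy. Chloro stays ahead, since methoxy in its place gives a 3.7-fold higher number from compound 2 to compound 4 (0.57 log units; beyond the scatter) and compound 2 is the strongest of the four.

Nothing measured here explains why these groups differ. Going by these compounds, whether an amine, a carboxylic acid or a bromo group on the phenyl ring would match chloro stays open, as does whether a longer chain on the oxygen would keep the level of methoxy.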